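From Nitro to Methoxy in One Swap

The source may report more compounds than this note shows. Statements on the series, on what has been measured and on what is new or still open speak of the compounds shown alone.

In a functional assay on TK-10 cells (Homo sapiens) for inhibition, read by sulforhodamine B assay, with a stated time of 24 h (a lower number here means a stronger inhibitor, a higher number a weaker inhibitor), compound 1 `Cc1ccc(C(=O)/C=C/c2ccc(C(=O)O)cc2)o1` gives 90000 nM. Compound 2 `COc1ccc(C(=O)/C=C/c2ccc(C(=O)O)cc2)cc1[N+](=O)[O-]` gives 21100 nM, the lower of the two numbers and so the stronger inhibitor, by a gap beyond the usual scatter. Compound 3 `COc1ccc(C(=O)/C=C/c2ccc(C(=O)O)cc2)cc1OC` differs from compound 2 by having methoxy in place of nitro on an aromatic carbon. Within the data shown here, no measured pair shows what this swap does, so only a small change is expected, with no shift beyond the scatter. The estimated step of a 1.4-fold higher number from compound 2 to compound 3 (0.15 log units; within the scatter) reflects that expectation. For compound 3, the expected value is 30000 nM, within a range of 11000 nM to 80000 nM.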

Compound 3, half-maximal inhibitory concentration: 18900 nM
For compound 3 the middle estimate is 1.6-fold (0.20 log units) above the measured one; the range from low to high includes it.
By their numbers in this assay, from the lowest: compounds 3 and 2 (each within the scatter of the next); then compound 1.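

Methoxy in place of nitro on this aromatic carbon, ortho to a methoxy group, gives a 1.1-fold lower number from compound 2 to compound 3 (0.05 log units; within the scatter) in this assay. The two groups differ in their atoms and in their hydrogen-bond acceptor counts, yet compound 2 and compound 3 cannot be told apart by this read-out. Nothing available explains this match. Still open, going by these compounds, is whether an amine or a bare hydrogen on this carbon would also read the same. On these data alone, a longer chain, such as ethoxy or propoxy, remains an equally open question.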